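Ethyl in Place of Ethoxy: An Expected Lipophilicity Shift

The source may report more compounds than this note shows. Statements on the series, on what has been measured and on what is new or still open speak of the compounds shown alone.

For the measured compounds named here, compound 2 `CCOc1ccc2[nH]c(-c3cccc(OC)c3)c(C3=C(Br)C(=O)NC3=O)c2c1` gives 2.97 in a physicochemical assay for lipophilicity (a higher number here means a more lipophilic compound, a lower number a more polar compound), one of only two numbers measured so far. The nearest is compound 1 `CCOc1ccc2[nH]c(-c3ccccc3)c(C3=C(Br)C(=O)NC3=O)c2c1`, which gives 2.77 in this assay. Going by the values given here, the only measured step reads a number 0.20 log units higher from compound 1 to compound 2 (within the scatter). Compound 3 `CCc1ccc2[nH]c(-c3cccc(OC)c3)c(C3=C(Br)C(=O)NC3=O)c2c1` differs from compound 2 by ethyl in place of ethoxy on an aromatic carbon. Among the compounds with values here, no measured step exchanges an alkoxy group for an alkyl group, so the expectation rests on the structural change alone. Compound 3 is therefore estimated at 3.45, within 3.05 to 3.9. The expected step is a number 0.48 log units higher from compound 2 to compound 3 (beyond the scatter), upward and beyond the scatter.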

Compound 3, partition coefficient: 3.35
Compound 3: middle estimate off by 0.10 log units, on the high side, within the range that was stated.
By their numbers in this assay, from the lowest: compounds 1 and 2 (each within the scatter of the next); then compound 3.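

In this assay the exchange of ethoxy for ethyl on this aromatic carbon gives a number 0.38 log units higher from compound 2 to compound 3 (beyond the scatter) and so, unlike a number 0.20 log units higher from compound 1 to compound 2 (within the scatter) for methoxy in place of hydrogen, it separates two compounds beyond the scatter. For the compounds shown here, this is the first reading of any change at this position, and it rests on a single pair. No measurement shown accounts for the size of this step.

The compounds shown leave open how an amine or a longer chain would read at this position. Going by these compounds, whether the same exchange gives a similar step on the core of compound 1 also remains open.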